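Inverting One Ring Stereocentre in Compound 2

A few compounds are considered here, and "the series" means these few. Any claim that something is new, unique, unknown or untested is made for them only; others in the source may bear on it.

- compound 1 `CCCCCCCCCCCNC[C@@H]1OC[C@H](N)[C@@H]1O`: 11100 nM
- compound 2 `CCCCCCCCCCCCNC[C@@H]1OC[C@H](N)[C@H]1O`: 41100 nM
- compound 3 `CCCCCCCCCCCCNC[C@@H]1OC[C@H](N)[C@@H]1O`: not yet measured

Both values come from a functional assay on A549 cells (Homo sapiens) for antiproliferative activity, read by MTT assay, with a stated time of 72 h; a lower number here means a stronger inhibitor, a higher number a weaker inhibitor. Compound 2, at 41100 nM, has the higher of the two numbers and is therefore the weaker inhibitor of the pair. Compound 1, at 11100 nM, is its nearest neighbour, and the gap between them lies beyond the scatter.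

Compound 3 keeps every atom and bond of compound 2. The change is the two compounds have the same atoms and bonds and differ only in configuration as drawn: 1 of 3 stereo elements differ; a stereocentre at a saturated ring carbon is drawn R in compound 2 and S in compound 3. No measured pair in this small set isolates such a change, so its effect in this assay has not been shown directly.

The expectation is therefore a judgement with wide margins. It leans toward a lower number, and compound 1 at 11100 nM provides the only measured reference point. The estimated change is a 3.4-fold lower number from compound 2 to compound 3 (0.53 log units; beyond the scatter), which would lie beyond the scatter. For compound 3 the expected value is 12000 nM, with an estimated range from 5000 nM to 28000 nM.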

Compound 3, half-maximal inhibitory concentration: 5870 nM
Compound 3: middle estimate off by 2.0-fold (0.31 log units), on the high side; the range from low to high includes it.
By their numbers in this assay, from the lowest: compounds 3 and 1 (each within the scatter of the next); then compound 2.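

In this assay, within the data shown here, inverting a stereocentre at a saturated ring carbon from R to S gives a 7.0-fold lower number from compound 2 to compound 3 (0.85 log units; beyond the scatter), the first direct reading of this change at this position. The step can be assigned to configuration alone, because nothing else separates the two compounds: the fact that compounds 2 and 3 differ only in the configuration as drawn. The chain, by contrast, gives no separable effect once the ring stereocentre is drawn S: methyl in place of hydrogen on a saturated chain carbon gives a 1.9-fold lower number from compound 1 to compound 3 (0.28 log units; within the scatter), so these two chain lengths cannot be told apart in this assay.

The compounds shown leave open whether the same inversion would give a step of similar size on the shorter chain of compound 1, and whether the other two stereo elements matter in this assay. They also leave open how a longer chain, or a carboxylic acid or amide in place of the chain amine, would read against compound 3.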